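The source may report more compounds than this note shows. Statements on the series, on what has been measured and on what is new or still open speak of the compounds shown alone.

Compound 1 `S=C(Nc1ccccc1)Nc1ccc2[nH]ccc2c1` gives 57500 nM in an ADME assay on cells for inhibition of Amine oxidase [flavin-containing] A (Homo sapiens), read by spectrophotometry; on this read-out lower numbers stand for stronger inhibition and higher numbers for weaker inhibition. Compound 2 `Oc1ccc(NC(=S)Nc2ccc3[nH]ccc3c2)cc1` reaches in this assay only a limit of the assay, > 100000 nM.

Compound 2 therefore stands at the limit marked in the limit of > 100000 nM in this assay, at which 1 of the 2 values shown sits, with no number of its own. Compound 3 `COc1ccc(NC(=S)Nc2ccc3[nH]ccc3c2)cc1` differs from it by methyl in place of hydrogen on an oxygen on an aromatic ring, hydroxy to methoxy. Within the data shown here, no measured step touches this change; the only measured step, an at least 1.7-fold higher number from compound 1 to compound 2 (0.24 log units; that floor lies within the scatter), concerns the hydroxy entering and sits at a floor within the scatter. From the limit alone, no step beyond the scatter is expected in this assay, a number no higher from compound 2 to compound 3 (the limit leaves the size open). Compound 3 is estimated at 100000 nM, between 35000 nM and 300000 nM.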

Compound 3, half-maximal inhibitory concentration: 36000 nM
Compound 3: the middle estimate sits 2.8-fold (0.44 log units) above what was measured; the range from low to high includes it.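

In this assay, methyl in place of hydrogen on an oxygen on an aromatic ring gives an at least 2.7-fold lower number from compound 2 to compound 3 (0.44 log units; beyond the scatter) and shows that this position responds to the change from hydroxy to methoxy. From the compounds shown here alone, the size of that step stays open because compound 2 holds only a limit: the limit of > 100000 nM in this assay, at which 1 of the 3 values shown sits. Adding the methoxy group gives a 1.6-fold lower number from compound 1 to compound 3 (0.20 log units; within the scatter) and leaves compound 3 not distinguishable from compound 1. The compounds shown leave open how an amine or a carboxylic acid at this position, or a longer chain on the oxygen, would read.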